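The source may report more compounds than this note shows. Statements on the series, on what has been measured and on what is new or still open speak of the compounds shown alone.

Compound 1 `CC(=O)Nc1ccc(O)c(C(=O)/C=C/c2cccc(F)c2)c1` and compound 2 `CC(=O)Nc1ccc(O)c(C(=O)/C=C/c2cccc(C(F)(F)F)c2)c1` share a core and differ in a single spot; compound 3 `CC(=O)Nc1ccc2oc(-c3ccc(F)cc3)c(O)c(=O)c2c1` and compound 4 `CC(=O)Nc1ccc2oc(-c3ccc(C(F)(F)F)cc3)c(O)c(=O)c2c1` share a second core, and the difference between the two cores is not broken down here. In an ADME assay on THP-1 cells (Homo sapiens) for cytotoxicity, read by flow cytometry and propidium iodide staining, with a stated time of 72 h (a higher number here means a weaker inhibitor, a lower number a stronger inhibitor), compound 1 gives 78600 nM, and compound 2 gives 8400 nM. On the same read-out compound 3 gives 26000 nM, which puts it between the other two measured compounds.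

The measured step, a 9.4-fold lower number from compound 1 to compound 2 (0.97 log units; beyond the scatter), rests on one change:
trifluoromethyl in place of fluoro on an aromatic carbon
Compound 4 is not yet measured, but it carries the same kind of change on its own core:
trifluoromethyl in place of fluoro on an aromatic carbon
The two changes are alike in what leaves and what enters, yet the surroundings differ: in the first the new group sits meta to a large group, in the second para to a large group, and the cores themselves are not the same.

He therefore expects a step for compound 4 in this assay of a 4.0-fold lower number from compound 3 to compound 4 (0.60 log units; beyond the scatter), smaller than the step from compound 1 to compound 2 because that step a 9.4-fold lower number from compound 1 to compound 2 (0.97 log units; beyond the scatter) was seen on a different core and in a different position. His estimate for compound 4 in this assay is 6500 nM, with a range from 2500 nM to 16000 nM.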

Compound 4, half-maximal inhibitory concentration: > 50000 nM
Compound 4 ended at the assay's limit; the forecaster's own chance of this, stated with the estimate: 5%; middle value at least 7.6-fold (0.88 log units) away from the limit.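

In this assay compound 4 gives > 50000 nM, which is a limit of the assay and not a number. The change of fluoro to trifluoromethyl on an aromatic carbon therefore gives an at least 1.9-fold higher number from compound 3 to compound 4 (0.28 log units; that floor lies within the scatter), and the step seen on the core of compound 1 did not carry over at its size to the core of compound 3: the same change on two cores in this assay, a 9.4-fold lower number (0.97 log units; beyond the scatter) from compound 1 to compound 2 and an at least 1.9-fold higher number (0.28 log units; that floor lies within the scatter) from compound 3 to compound 4, at least 17-fold (1.25 log units) apart, beyond the scatter of two such steps. Going by these compounds, this rests on one pair per core and does not show whether the core or the place of the group accounts for the gap, and the full size of the new step stays unknown since compound 4 stands at the limit: the limit of > 50000 nM in this assay, at which 1 of the 4 values shown sits.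

The compounds shown leave open whether the two cores would give matching steps if the trifluoromethyl stood in the same place on both. They also leave open how a nitrile, an amine or a carboxylic acid in that place would read on the core of compound 3.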